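A few compounds are considered here, and "the series" means these few. Any claim that something is new, unique, unknown or untested is made for them only; others in the source may bear on it.

Measured so far in a functional assay on XF498 cells (Homo sapiens) for cytotoxicity; a lower number here means that less compound is needed, a higher number that more compound is needed for the effect:
compound 1, `CC1=C(O)[C@@H](C/C(C)=C\CCC(C)/C=C/C=C(\C)CCCc2ccoc2)OC1=O`, 24.8 ug/mL
compound 2, `CC1=C(O)[C@@H](C/C(C)=C\CCC(C)/C=C/C/C(C)=C/CCc2ccoc2)OC1=O`, 20.4 ug/mL

Compound 1 has the highest of the two numbers in this assay, with compound 2 the nearest, and the gap between the two values is within the scatter, so no order between them can be read from these data. Both compounds share the same core and differ only in the chain that carries the furan.

Compound 3, `CC1=C(O)[C@H](C/C(C)=C\CCC(C)/C=C\C=C(\C)CCCc2ccoc2)OC1=O`, has not yet been measured. It differs from compound 1 as follows: the two compounds have the same atoms and bonds; at least one stereo element is drawn with a configuration in one of them and without one in the other: 3 of 5 stereo elements differ; a stereocentre at a saturated ring carbon is drawn R in compound 1 and S in compound 3; a double bond is drawn E in compound 1 and Z in compound 3; a double bond is drawn E in compound 1 and Z in compound 3. Among the measured compounds shown here, no pair of measured compounds shows what such a change of stereo elements does in this assay, so no measured step can be used as a guide. With the same atoms and bonds, and with compounds 1 and 2 sitting close together despite a difference in their chains, the expectation for compound 3 is a step of a 1.0-fold higher number from compound 1 to compound 3 (0.00 log units; within the scatter) that stays within the scatter, in no firm direction. Compound 3 is therefore estimated at 25 ug/mL in this assay, with a range from 10 ug/mL to 60 ug/mL.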

Compound 3, concentration for half-maximal effect: 8.89 ug/mL
Estimate against measurement, compound 3: 2.8-fold (0.45 log units) above; measured number below the stated range.
By their numbers in this assay, from the lowest: compound 3; then compounds 2 and 1 (each within the scatter of the next).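

In this assay the stereo elements alone move the number: the saturated ring carbon going from R to S and two double bonds going from E to Z give a 2.8-fold lower number from compound 1 to compound 3 (0.45 log units; beyond the scatter) with no atom entering or leaving. The earlier compounds shown here did not show this: compound 1 and compound 2 lie within the scatter of each other, and neither pair offered a comparison with atoms and bonds held fixed. The three stereo elements changed together, so the step belongs to the set as a whole and not to any one of them, and its reading carries a further limit: the fact that one of compounds 1 and 3 is drawn with a defined configuration and the other without, at the place where they differ

Which of the ring stereocentre and the two double bonds carries the step stays open, and separating them would take a compound with only the stereocentre inverted or only one double bond changed. Also open, from the compounds shown here alone, is whether a step of this size persists when the furan at the end of the chain gives way to another end group, such as a phenyl ring or a carboxylic acid.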